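Swapping tert-butyl for iodo on the aromatic ring

A few compounds are considered here, and "the series" means these few. Any claim that something is new, unique, unknown or untested is made for them only; others in the source may bear on it.

Measured in a functional assay on HT-29 cells (Homo sapiens) for inhibition, read by sulforhodamine B assay, with a stated time of 48 h; a higher number here means a weaker inhibitor of growth, a lower number a stronger inhibitor of growth:
- Compound 1 `c1ccc(-c2ccc(NC3=NCCO3)cc2)cc1`: 5800 nM
- Compound 2 `c1cc(OC2CCCC2)ccc1NC1=NCCO1`: 16100 nM
- Compound 3 `CC(C)(C)c1ccc(NC2=NCCO2)cc1`: 1500 nM

Of these three, compound 3 stands lowest at 1500 nM, which makes it the strongest growth inhibitor so far. Compound 4 `Ic1ccc(NC2=NCCO2)cc1` keeps the shared core but carries iodo in place of tert-butyl on an aromatic carbon.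

For the measured compounds named here, no measured compound carries iodo, so the known steps offer only a sense of scale. Two of them end on tert-butyl: a 3.9-fold lower number from compound 1 to compound 3 (0.59 log units; beyond the scatter) and an 11-fold lower number from compound 2 to compound 3 (1.03 log units; beyond the scatter). The third, a 2.8-fold higher number from compound 1 to compound 2 (0.44 log units; beyond the scatter), shows that the other two groups also differ from each other. Neither of the other groups matches tert-butyl, so losing it is expected to give a modest move towards a higher number in this assay, though the direction remains uncertain with so few compounds.

The estimated step is a 2.3-fold higher number from compound 3 to compound 4 (0.37 log units; beyond the scatter). For compound 4 the expected value is 3500 nM, with an estimated range of 1200 nM to 10000 nM.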

Compound 4, concentration for 50% growth inhibition: 1300 nM
Beside the measured number, compound 4's estimate is 2.7-fold (0.43 log units) above it; measured number inside the range.
By their numbers in this assay, from the lowest: compounds 4 and 3 (each within the scatter of the next); then compound 1; then compound 2.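

In this assay, iodo and tert-butyl cannot be told apart at this place on the aromatic ring (a 1.2-fold lower number from compound 3 to compound 4 (0.06 log units; within the scatter)), even though one heavy atom enters where four leave, so among these compounds the heavy-atom count of the group does not set the number. Iodo also keeps the gaps to the other two groups that tert-butyl showed, with a 12-fold lower number from compound 2 to compound 4 (1.09 log units; beyond the scatter) and a 4.5-fold lower number from compound 1 to compound 4 (0.65 log units; beyond the scatter), so cyclopentyloxy and phenyl are not the only contrast to tert-butyl: a second group now stands apart from them. Nothing measured here explains why these two groups match.

Going by these compounds, whether this match extends to other single atoms, such as chloro or fluoro, stays open. So does the effect of an amine or a carboxylic acid at this place, and the shared core has not been varied in these compounds.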